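This account rests on a few compounds, and the source may have more. Where it says the series, first, only, none or still open, it means among the compounds named here.

In a functional assay on the whole organism with Rattus norvegicus as the target, read by paw edema, with a stated time of 3 h, at a dose of 100 mg/kg by the oral route (a lower number here means less inhibition, a higher number more inhibition at the dose given (going by the name of the read-out)), three compounds built on one shared core have been measured so far. Compound 1 `Cc1ccc(-c2nc3ccccc3[nH]2)nc1` gives 19%. Compound 2 `Cc1cccc(-c2nc3ccccc3[nH]2)n1` gives 44%, and compound 3 `CCc1cccc(-c2nc3ccccc3[nH]2)n1` gives 41%. Compound 1 therefore stands lowest of the three, and both of the other numbers lie beyond the scatter above it, with compound 3 the nearer and compound 2 the further away. Among the measured compounds shown here, only one measured pair differs in a single place, and that pair shows a number 3 percentage points lower from compound 2 to compound 3 (within the scatter), a change that stays within the scatter.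

Compound 4 `OCc1ccc(-c2nc3ccccc3[nH]2)nc1` has not yet been measured in this assay. It differs from compound 1 by hydroxy in place of hydrogen on a saturated chain carbon bound to an aromatic carbon. For the measured compounds named here, the single measured step that bears on this change is the one already named, which alters the same kind of saturated chain carbon bound to an aromatic carbon, though with a methyl rather than a hydroxy group entering, and it was within the scatter. Because that step was a number 3 percentage points lower from compound 2 to compound 3 (within the scatter), no step beyond the scatter is expected here either, in either direction. Compound 4 is accordingly estimated to give 22%, with a range from 5% to 40%. The expected step is a number 3 percentage points higher from compound 1 to compound 4 (within the scatter).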

Compound 4, a percentage reported as inhibition, in the whole organism at one dose (the size of the read-out at that dose, not a potency): -10%
Compound 4: the middle estimate sits 32 percentage points above what was measured, outside the stated range (below it).
By their numbers in this assay, from the lowest: compound 4; then compound 1; then compounds 3 and 2 (each within the scatter of the next).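

In this assay, hydroxy in place of hydrogen on a saturated chain carbon bound to an aromatic carbon gives a number 29 percentage points lower from compound 1 to compound 4 (beyond the scatter) and so shows that this place on the shared core does respond to a change, with compound 4 at -10% recording no inhibition at the dose given. Among the compounds shown here, the only earlier step at such a carbon, a number 3 percentage points lower from compound 2 to compound 3 (within the scatter), brought in methyl on a different parent, so the two steps together show that a quiet result with one entering group on one compound does not carry over to hydroxy on another. Nothing measured here explains why the number falls with this change.

Going by these compounds, it remains open whether hydroxy itself matters or whether methoxy, an amine or a carboxylic acid on the same carbon would give a similar fall. On these data alone, it also remains open whether the same change, methyl to hydroxymethyl, would give a step of this size on compound 2 , the parent with the higher number.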